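The compounds below may be only part of what the source reports. "The series", "measured", "known", "first", "only" and "open" are said of these compounds alone.

Compound 2 `COc1cccc(F)c1C1CCN(c2ccn3c(CC4CC4)nnc3c2Cl)CC1` holds the lowest number of the two measured compounds in a functional assay on CHO cells for agonist activity at metabotropic glutamate receptor 2 (Homo sapiens), read by scintillation counting and GTPgammaS binding, with a stated time of 30 min (on this read-out higher numbers stand for an effect only at larger amounts of compound and lower numbers for an effect already at smaller amounts), at 6 nM; compound 1 `COc1c(F)cccc1C1CCN(c2ccn3c(CC(F)(F)F)nnc3c2C#N)CC1` gives 31 nM, a gap beyond the usual scatter. Compound 3 `COc1c(F)ccc(F)c1C1CCN(c2ccn3c(CC4CC4)nnc3c2Cl)CC1` is compound 2 with a single change: fluoro in place of hydrogen on an aromatic carbon, a fluoro in place of hydrogen on an aromatic carbon. Going by the values given here, no measured pair shows this change, so a step of this kind is expected to stay within the scatter, with no clear direction. The expected step from compound 2 to compound 3 in this assay is a 1.3-fold higher number from compound 2 to compound 3 (0.12 log units; within the scatter). Compound 3 is estimated at 8 nM, most likely between 3 nM and 20 nM.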

Compound 3, half-maximal effective concentration: 7.5 nM
Compound 3: the middle estimate sits 1.1-fold (0.03 log units) above what was measured; the measured number falls inside the stated range.
By their numbers in this assay, from the lowest: compounds 2 and 3 (each within the scatter of the next); then compound 1.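

In this assay, a fluoro in place of hydrogen on the aromatic carbon ortho to a methoxy group gives a 1.3-fold higher number from compound 2 to compound 3 (0.10 log units; within the scatter) and so leaves the two compounds indistinguishable on this read-out. This first pair differing in one place shows that this position accepts a fluoro, with the number still in the same low range. No available evidence explains this result. Going by these compounds, whether an amine or a carboxylic acid at this position would be accepted stays open. So does whether a fluoro here behaves the same with the trifluoroethyl group and nitrile of compound 1.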